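Swapping 2-methylphenyl for 4-chlorophenyl: working notes

The compounds below may be only part of what the source reports. "The series", "measured", "known", "first", "only" and "open" are said of these compounds alone.

Measured so far in a functional assay on HCT-15 cells (Homo sapiens) for cytotoxicity, read by ELISA, with a stated time of 4 days (a higher number here means a weaker inhibitor, a lower number a stronger inhibitor), as half-maximal inhibitory concentrations:
- compound 1 `Cc1ccsc1-c1cc(-c2ccco2)cc(-c2ccccc2Cl)n1` gives 540 nM
- compound 2 `Cc1ccsc1-c1cc(-c2ccoc2)cc(-c2ccco2)n1` gives 640 nM
- compound 3 `Cc1ccccc1-c1cc(-c2ccoc2)cc(-c2ccc(Cl)s2)n1` gives 990 nM

Compound 3 (990 nM) lies within the scatter of both compound 1 and compound 2, so the three values cannot be ranked. Compound 4 `Clc1ccc(-c2cc(-c3ccoc3)cc(-c3ccc(Cl)s3)n2)cc1` has 4-chlorophenyl in place of 2-methylphenyl on an aromatic carbon. Within the data shown here, no measured pair differs in one place, so nothing isolates this change. In this assay no step beyond the scatter is expected, in either direction. The estimated step is a 1.1-fold lower number from compound 3 to compound 4 (0.04 log units; within the scatter) and stays within the scatter. For compound 4 the estimate is 900 nM with an expected range from 350 nM to 2500 nM for now.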

Compound 4, half-maximal inhibitory concentration: 640 nM
Estimate against measurement, compound 4: 1.4-fold (0.15 log units) above; measured number inside the range.
By their numbers in this assay, from the lowest: compounds 1, 2, 4 and 3 (each within the scatter of the next).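

Among these compounds, this is the first comparison that differs in one place: at the aromatic carbon next to the ring nitrogen, 4-chlorophenyl in place of 2-methylphenyl gives a 1.5-fold lower number from compound 3 to compound 4 (0.19 log units; within the scatter) in this assay. At this position, with the furan-3-yl and 5-chlorothiophen-2-yl groups held fixed, the assay does not separate these two groups. No available data explain this result.

Going by these compounds, whether an amine or a carboxylic acid at this position would give a step beyond the scatter remains open. Also open, on these data alone, is whether the same swap stays within the scatter when the furan-3-yl or 5-chlorothiophen-2-yl group is replaced.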